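The source may report more compounds than this note shows. Statements on the series, on what has been measured and on what is new or still open speak of the compounds shown alone.

In a functional assay on the whole organism (plasma, strain Sprague-Dawley) with Rattus norvegicus as the target, with a stated time of 2 h, at a dose of 100 mg/kg by the oral route (a higher number here means a stronger effect of the compound at the dose given, a lower number a weaker effect), three compounds have been measured. Compound 1 `c1ccc(C(/N=C2\CCCCCCN2)C2CC2)cc1` gives 58%, compound 2 `c1ccc2c(C(/N=C3\CCCCCN3)C3CC3)cccc2c1` gives 21%, and compound 3 `c1ccc(C(/N=C2\CCCCCN2)C2CCC2)cc1` gives 44%. Compound 3 therefore stands second highest of the three numbers: its nearest neighbour is compound 1, whose number is higher by a margin beyond the scatter, and its furthest is compound 2, whose number is lower by a margin also beyond the scatter. Compound 4 `c1ccc(C(/N=C2\CCCCCN2)C2CCCCCC2)cc1` differs from compound 3 in one place: cycloheptyl in place of cyclobutyl on a saturated chain carbon bound to an aromatic carbon and a double-bonded nitrogen. Among the compounds with values here, no measured pair shows a step of this kind, so its size in this assay is unknown; a change within the scatter, or a modest fall, is expected. Compound 4 is estimated at 35%, within 10% to 60%. This expected step is a number 9 percentage points lower from compound 3 to compound 4 (within the scatter).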

Compound 4, a percentage reported as inhibition, in the whole organism at one dose (the size of the read-out at that dose, not a potency): 6%
Compound 4: middle estimate off by 29 percentage points, on the high side; measured number below the stated range.
By their numbers in this assay, from the lowest: compound 4; then compound 2; then compound 3; then compound 1.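

Placing cycloheptyl in place of cyclobutyl on the saturated chain carbon bound to an aromatic carbon and a double-bonded nitrogen gives a number 38 percentage points lower from compound 3 to compound 4 (beyond the scatter) in this assay. Within the data shown here, this is the first reading of a single change here, and it shows that the effect at this dose depends strongly on which ring this carbon carries. Nothing available explains the fall. On these data alone, whether cyclopentyl or cyclohexyl at this place would stay closer to compound 3 or to compound 4 remains open. Cyclopropyl occurs only in compounds that differ elsewhere too, so its standing here cannot be read.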